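Replacing the Phenylethenyl Group: An Expected Shift

A few compounds are considered here, and "the series" means these few. Any claim that something is new, unique, unknown or untested is made for them only; others in the source may bear on it.

Three compounds share one core and differ only at a single saturated ring carbon. In a functional assay on NCI-H226 cells (Homo sapiens) for antiproliferative activity, with a stated time of 48 h (on this read-out higher numbers stand for weaker inhibition of growth and lower numbers for stronger inhibition of growth), compound 1 `Cc1cc(O)c(C2=NN(c3ccc(S(N)(=O)=O)cc3)C(c3ccccc3O)C2)cc1Cl` gives 7550 nM, compound 2 `Cc1cc(O)c(C2=NN(c3ccc(S(N)(=O)=O)cc3)C(c3ccccc3Cl)C2)cc1Cl` gives 9440 nM, and compound 3 `Cc1cc(O)c(C2=NN(c3ccc(S(N)(=O)=O)cc3)C(/C=C/c3ccccc3)C2)cc1Cl` gives 19200 nM, the highest of the three, so compound 3 inhibits growth least. Compound 4 `COc1ccc(C2CC(c3cc(Cl)c(C)cc3O)=NN2c2ccc(S(N)(=O)=O)cc2)cc1OC` carries 3,4-dimethoxyphenyl in place of 2-phenylethenyl on a saturated ring carbon. The measured steps that bear on this are a 2.5-fold higher number from compound 1 to compound 3 (0.41 log units; beyond the scatter) and a 2.0-fold higher number from compound 2 to compound 3 (0.31 log units; beyond the scatter): exchanging a 2-hydroxyphenyl or 2-chlorophenyl group for the 2-phenylethenyl group raised the number modestly each time. Returning to an aromatic group is therefore expected to lower the number modestly, roughly a 2.1-fold lower number from compound 3 to compound 4 (0.33 log units; beyond the scatter). For compound 4 in this assay the estimate is 9000 nM, with an expected range from 4000 nM to 20000 nM.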

Compound 4, concentration for total growth inhibition: 23100 nM
Estimate against measurement, compound 4: 2.6-fold (0.41 log units) below, outside the stated range (above it).
By their numbers in this assay, from the lowest: compounds 1 and 2 (each within the scatter of the next); then compounds 3 and 4 (each within the scatter of the next).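

In this assay, putting an aromatic group at this saturated ring carbon does not by itself lower the number, as a 1.2-fold higher number from compound 3 to compound 4 (0.08 log units; within the scatter) lies within the scatter. What that ring carries matters, as 3,4-dimethoxyphenyl gives weaker inhibition of growth than 2-chlorophenyl or 2-hydroxyphenyl, with a 2.4-fold higher number from compound 2 to compound 4 (0.39 log units; beyond the scatter) and a 3.1-fold higher number from compound 1 to compound 4 (0.49 log units; beyond the scatter) both beyond the scatter. No measurement shown here explains these differences.

The compounds shown leave open how an unsubstituted phenyl, or a phenyl bearing an amine, would compare at this carbon. They also leave open whether a single methoxy group would match the pair.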